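Thiophen-2-yl for 4-Fluorophenyl on a Shared Core

The source may hold more compounds than are shown below. What is called first, only, known or untested is meant among the compounds shown, and "the series" means these compounds.

Measured in a functional assay on SK-OV-3 cells (Homo sapiens) for inhibition, read by MTT assay, with a stated time of 24 h; a higher number here means a weaker inhibitor, a lower number a stronger inhibitor:
compound 1 `CCOC(=O)c1c(C)[nH]c(=O)c(C#N)c1-c1ccc([N+](=O)[O-])cc1` gives > 100000 nM, a limit of the assay.
compound 2 `CCOC(=O)c1c(C)[nH]c(=O)c(C#N)c1-c1ccc(F)cc1` gives > 100000 nM, also a limit of the assay.

Compound 2 thus stands at the limit of this assay rather than at a number. For the measured compounds named here, the only step among the measured compounds, a step that the two limits leave unreadable from compound 1 to compound 2, cannot be sized because of the limit of > 100000 nM in this assay, at which 2 of the 2 values shown sit. The shared core of compound 1 and compound 2 has so far shown no readable inhibition at all.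

Compound 3 `CCOC(=O)c1c(C)[nH]c(=O)c(C#N)c1-c1cccs1` is not yet measured. It differs from compound 2 in one place: thiophen-2-yl in place of 4-fluorophenyl on an aromatic carbon. Going by the values given here, no measured step bears readably on this change, since the one available step is hidden by the limits. With both neighbours sitting at the limit, the step from compound 2 to compound 3 is expected to stay unreadable in this assay, with no direction beyond the scatter that the data could support; the expected step is a step that the limit leaves unreadable from compound 2 to compound 3. Compound 3 is therefore estimated to give 200000 nM in this assay, within a range of 50000 nM to 1000000 nM, and most likely to be reported only as a limit again.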

Compound 3, half-maximal inhibitory concentration: 97300 nM
The estimate for compound 3 lay 2.1-fold (0.31 log units) above the measured number; the range from low to high includes it.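

In this assay, for the compounds shown here, compound 3 gives 97300 nM, the only actual number on the shared core so far, which shows that a readable value can be obtained at this position, opposite the ring nitrogen, when thiophen-2-yl stands there. Replacing 4-fluorophenyl with thiophen-2-yl gives an at least 1.0-fold lower number from compound 2 to compound 3 (0.01 log units; that floor lies within the scatter), so the data establish only a floor for this change and not a gain beyond the usual scatter. The real size of the step may be larger, but it cannot be told, because one side of it is a limit rather than a number: the limit of > 100000 nM in this assay, at which 2 of the 3 values shown sit.

The compounds shown leave open whether the value of compound 3 would hold or move further with a different group at this position, such as a phenyl ring carrying an amine or a carboxylic acid. They also leave open how this assay would respond to changes elsewhere on the shared core, such as a longer chain in place of the methyl group or a carboxylic acid in place of the ethoxycarbonyl group.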